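Methoxymethyl to ethoxymethyl on compound 2

This account rests on a few compounds, and the source may have more. Where it says the series, first, only, none or still open, it means among the compounds named here.

Compound 1 `Cc1cc(CCCOc2c(C)cc(-c3noc(C)n3)cc2C)on1`: 0.45 h
Compound 2 `COCc1cc(CCCOc2c(C)cc(-c3noc(C(F)(F)F)n3)cc2C)on1`: 1.58 h

In an in vitro ADME assay on microsomes from liver (Simiiformes) (a higher number here means that the compound lasts longer, a lower number that the compound disappears faster), compound 2 stands highest of the two at 1.58 h, while compound 1 gives 0.45 h, a gap beyond the scatter. These two differ in more than one place, so their gap cannot be pinned on any single group.

Compound 3 `CCOCc1cc(CCCOc2c(C)cc(-c3noc(C(F)(F)F)n3)cc2C)on1` turns the methoxymethyl of compound 2 into ethoxymethyl: methyl in place of hydrogen on a saturated chain carbon bound to an oxygen on a saturated carbon. Within the data shown here, no measured pair shows this change. The estimated step, a 1.3-fold lower number from compound 2 to compound 3 (0.12 log units; within the scatter), is a small drop that stays within the scatter. For compound 3 the expected half-life is 1.2 h, with an estimated range from 0.6 h to 2.4 h.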

Compound 3, half-life: > 2.5 h
Compound 3 was reported as a limit (the forecaster's own chance of this, stated with the estimate: 3%); at least 2.0-fold (0.31 log units) between middle value and limit.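

In this assay compound 3 gives > 2.5 h, which is a limit of the assay and not an exact number. This is the only single-place step among these compounds, and it reads an at least 1.5-fold higher number from compound 2 to compound 3 (0.19 log units; that floor lies within the scatter), so the added methyl shows no loss of half-life, though that floor alone does not prove a gain. How far the step reaches cannot be read, because the value sits at a limit: the limit of > 2.5 h in this assay, at which 1 of the 3 values shown sits.

Still open, on these data alone, is whether a longer chain such as propoxymethyl, or an amine at this place, would keep the half-life. Also open, as far as these compounds go, is whether ethoxymethyl behaves the same way with methyl in place of trifluoromethyl.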